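From Methyl to Phenyl on a Ring Amine Nitrogen

The compounds below may be only part of what the source reports. "The series", "measured", "known", "first", "only" and "open" are said of these compounds alone.

Compound 1 `CS(=O)(=O)c1ccc(C(=O)N2CCC(C(=O)N3CCN(c4ccc(F)cc4)CC3)CC2)cc1[N+](=O)[O-]`: in an ADME assay on HepG2 cells (Homo sapiens) for cytotoxicity, read by CellTiter-Glo and ATP content, with a stated time of 72 h (on this read-out higher numbers stand for an effect only at larger amounts of compound and lower numbers for an effect already at smaller amounts), compound 1 gives > 27000 nM, which is a limit of the assay and not a number.
Compound 2 `CN1CCN(C(=O)C2CCN(C(=O)c3ccc(S(C)(=O)=O)c([N+](=O)[O-])c3)CC2)CC1`: in this assay compound 2 gives > 27000 nM, again a limit rather than a number.

Going by the values given here, compound 2 therefore stands at the upper edge of what this assay reports, and so does the only other compound measured here; both sit at the limit of > 27000 nM in this assay, at which 2 of the 2 values shown sit. Among the compounds with values here, the one step between measured compounds, a step that the two limits leave unreadable from compound 1 to compound 2, cannot be read for size because both of its ends are limits.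

Compound 3 `CS(=O)(=O)c1ccc(C(=O)N2CCC(C(=O)N3CCN(c4ccccc4)CC3)CC2)cc1[N+](=O)[O-]` differs from compound 2 in one place: phenyl in place of methyl on an amine nitrogen in a ring. The measured step that bears on this change is the step from compound 1 to compound 2, which runs in the opposite sense and remained unreadable. Within the data shown here, nothing in the numbers so far points to a change in either direction beyond the scatter, and the expectation is that compound 3 again returns a limit. The estimate for compound 3 is 40000 nM, with a range from 15000 nM to 120000 nM, so that the expected step that the limit leaves unreadable from compound 2 to compound 3 is none that the assay can resolve.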

Compound 3, half-maximal effective concentration: > 27000 nM
Compound 3 was reported as a limit (the forecaster's own chance of this, stated with the estimate: 80%); the middle value does not contradict the limit.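

Going by these compounds alone, no step among compound 1, compound 2 and compound 3 can be read in this assay because all three values are limits of the assay and not numbers: (the limit of > 27000 nM in this assay, at which 3 of the 3 values shown sit).

The compounds shown leave open whether phenyl in place of methyl, or hydrogen in place of fluoro, changes the read-out at all.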